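Amino for chloro: a second test of the same step

The source may hold more compounds than are shown below. What is called first, only, known or untested is meant among the compounds shown, and "the series" means these compounds.

Compound 1 `ClCc1ccccc1Cn1cnc2c(Cl)nc(Cl)nc21` and compound 2 `ClCc1cccc(Cn2cnc3c(Cl)nc(Cl)nc32)c1` are built from the same atoms joined differently; how the two cores differ is not broken down here. In a functional assay on UO-31 cells (Homo sapiens) for cytotoxicity, read by sulforhodamine B assay, with a stated time of 48 h (a lower number here means that less compound is tolerated, a higher number that more compound is tolerated), compound 1 gives 5920 nM. In this assay compound 2 gives 5880 nM, within the scatter of compound 1. Compound 3 `Nc1nc(Cl)c2ncn(Cc3ccccc3CCl)c2n1` reaches only a limit of the assay in this assay, namely > 100000 nM. The change from compound 1 to compound 3 is amino in place of chloro on an aromatic carbon, and it produced an at least 16-fold higher number from compound 1 to compound 3 (1.22 log units; beyond the scatter), with compound 3 sitting at the limit of > 100000 nM in this assay, at which 1 of the 3 values shown sits. Compound 4 `Nc1nc(Cl)c2ncn(Cc3cccc(CCl)c3)c2n1`, not yet measured, differs from compound 2 by amino in place of chloro on an aromatic carbon, the same change at the same place. The expectation for compound 4 rests on that earlier step an at least 16-fold higher number from compound 1 to compound 3 (1.22 log units; beyond the scatter) starting from a value that compound 1 and compound 2 share within the scatter. Compound 4 is therefore expected to give 100000 nM, a step of a 17-fold higher number from compound 2 to compound 4 (1.23 log units; beyond the scatter), and most likely only a limit in this assay.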

Compound 4, concentration lethal to 50% of the cells: 77600 nM
The estimate for compound 4 lay 1.3-fold (0.11 log units) above the measured number, and the stated range covers the measured number.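

In this assay amino in place of chloro on an aromatic carbon gives a 13-fold higher number from compound 2 to compound 4 (1.12 log units; beyond the scatter) and so carries over to a second core. Set beside the earlier case, the change moves the number the same way on both cores: the same change on two cores in this assay, an at least 16-fold higher number (1.22 log units; beyond the scatter) from compound 1 to compound 3 and a 13-fold higher number (1.12 log units; beyond the scatter) from compound 2 to compound 4; the limit leaves it open whether they differ. Compound 3 at > 100000 nM is a limit of the assay and not a number, and two cores make no rule for the wider series.

From the compounds shown here alone, whether a methylamino group, a dimethylamino group or a hydroxyl in the same place would follow the amino group stays open. Also open, going by these compounds, is whether the step would hold with a longer chain in place of the chloromethyl group.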